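The source may hold more compounds than are shown below. What is called first, only, known or untested is meant among the compounds shown, and "the series" means these compounds.

Compound 3, `COc1ccc(-c2ccc([C@@H](c3ccccc3)[C@@](O)(CCN(C)C)c3cccc4ccccc34)c(OC)n2)cc1`, stands in a toxicity assay on HeLa cells (Homo sapiens) for cytotoxicity (a lower number here means that less compound is tolerated, a higher number that more compound is tolerated), only at a limit: in this assay compound 3 gives > 64 ug/mL, which is a limit of the assay and not a number. Compound 2, `COc1nc(-c2ccc(F)cc2)ccc1[C@@H](c1ccccc1)[C@@](O)(CCN(C)C)c1cccc2ccccc12`, is known in this assay in the same way, as compound 2 gives > 64 ug/mL, again a limit. Compound 1, `COc1nc(-c2cccc(Cl)c2)ccc1[C@@H](c1ccccc1)[C@@](O)(CCN(C)C)c1cccc2ccccc12`, gives "nd" (no result reported) in this assay. Among the measured compounds shown here, the one step between measured compounds, a step that the two limits leave unreadable from compound 2 to compound 3, therefore cannot be read; the most that the data show is the limit of > 64 ug/mL in this assay, at which 2 of the 3 values shown sit.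

Compound 4, `COc1nc(-c2ccc(OC(F)(F)F)cc2)ccc1[C@@H](c1ccccc1)[C@@](O)(CCN(C)C)c1cccc2ccccc12`, differs from compound 3 by trifluoromethyl in place of methyl on an oxygen on an aromatic ring. For the measured compounds named here, no measured step speaks readably to this change, and the two limits give no direction. On that footing compound 4 is expected, in this assay, to give about 80 ug/mL, with a range from 32 ug/mL to 200 ug/mL. The step that the limit leaves unreadable from compound 3 to compound 4 is thus estimated to stay within the scatter of the method, with the result most likely reported again only as a limit.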

Compound 4, half-maximal cytotoxic concentration: > 64 ug/mL
Compound 4 was reported as a limit (the forecaster's own chance of this, stated with the estimate: 70%); the middle value does not contradict the limit.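

In this assay, among the compounds shown here, compound 4 gives > 64 ug/mL, which is a limit of the assay and not a number, so no step among compound 2, compound 3 and compound 4 can be read. The compounds shown leave open whether fluoro, methoxy and trifluoromethoxy differ at all in this assay.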